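Replacing the thiophene of compound 3 with cyclopropyl

The source may hold more compounds than are shown below. What is called first, only, known or untested is meant among the compounds shown, and "the series" means these compounds.

Measured compounds:
Compound 1, `CCOC(=O)c1cnc(-c2csc(C)n2)nc1NN1C(=O)C=C(C)C1=O`, 8000 nM
Compound 2, `CCOC(=O)c1cnc(-n2nc(C)cc2C)nc1NN1C(=O)C=C(C)C1=O`, 10000 nM
Compound 3, `CCOC(=O)c1cnc(-c2ccsc2)nc1NN1C(=O)C=C(C)C1=O`, 100 nM

In a functional assay on Jurkat cells for inhibition of nuclear factor NF-kappa-B complex (Homo sapiens) (on this read-out higher numbers stand for weaker inhibition and lower numbers for stronger inhibition), compound 3 gives 100 nM, the lowest number of the three; the step is an 80-fold lower number from compound 1 to compound 3 (1.90 log units; beyond the scatter) and a 100-fold lower number from compound 2 to compound 3 (2.00 log units; beyond the scatter), while a 1.3-fold higher number from compound 1 to compound 2 (0.10 log units; within the scatter). The compound not yet measured is compound 4, `CCOC(=O)c1cnc(C2CC2)nc1NN1C(=O)C=C(C)C1=O`. It differs from compound 3 in one place: cyclopropyl in place of thiophen-3-yl on an aromatic carbon. Among the measured compounds shown here, no measured step exchanges an aromatic ring at this position for a non-aromatic one, so none bears on it directly. The two measured changes at the same position, both to a different five-membered aromatic ring, each moved this assay by a large amount, which suggests that this position is sensitive to what stands there. Compound 4 is therefore expected to give a higher number than compound 3, by a 20-fold higher number from compound 3 to compound 4 (1.30 log units; beyond the scatter), with wide uncertainty. The estimate for compound 4 in this assay is 2000 nM, ranging from 300 nM to 15000 nM.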

Compound 4, half-maximal inhibitory concentration: 1000 nM
Beside the measured number, compound 4's estimate is 2.0-fold (0.30 log units) above it, within the range that was stated.
By their numbers in this assay, from the lowest: compound 3; then compound 4; then compounds 1 and 2 (each within the scatter of the next).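

In this assay, a non-aromatic ring on the aromatic carbon between two ring nitrogen atoms still ranks ahead of two of the aromatic rings, with a 10-fold lower number from compound 2 to compound 4 (1.00 log units; beyond the scatter) and an 8.0-fold lower number from compound 1 to compound 4 (0.90 log units; beyond the scatter) as the steps. It does not match thiophen-3-yl, however, as a 10-fold higher number from compound 3 to compound 4 (1.00 log units; beyond the scatter) shows. Cyclopropyl thus falls between the aromatic rings of the earlier compounds, so in these four compounds, whether the ring is aromatic does not by itself set the order, and compound 3 and compounds 1 and 2 lie on opposite sides of compound 4. No evidence is available that would explain this order.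

The compounds shown leave open how a larger saturated ring such as cyclohexyl, an open chain such as isopropyl, or an amine such as morpholine would rank here. They also leave open whether phenyl or thiophen-2-yl would stay close to thiophen-3-yl.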